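Fluorines in Place of Methoxy on the Ketone Aryl

The source may hold more compounds than are shown below. What is called first, only, known or untested is meant among the compounds shown, and "the series" means these compounds.

Among the measured compounds shown here, compound 2 `COc1ccc(C(=O)/C=C/c2cc(-c3cc(OC)c(OC)c(OC)c3)n[nH]2)cc1` gives 3040 nM in a functional assay on NCI-H23 cells (Homo sapiens) for inhibition, read by sulforhodamine B assay, with a stated time of 48 h (a lower number here means a stronger inhibitor of growth, a higher number a weaker inhibitor of growth), the highest of the two numbers known so far; compound 1 `COc1ccc(C(=O)/C=C/c2cc(-c3cc(OC)c(OC)c(OC)c3)n[nH]2)cc1OC` gives 2150 nM, and the step of a 1.4-fold higher number from compound 1 to compound 2 (0.15 log units; within the scatter) lies within the scatter. Compound 3 `COc1cc(-c2cc(/C=C/C(=O)c3ccc(F)c(F)c3)[nH]n2)cc(OC)c1OC` differs from compound 2 by 3,4-difluorophenyl in place of 4-methoxyphenyl on a carbonyl carbon. For the measured compounds named here, no measured step covers this exchange; the one known step, hydrogen in place of methoxy on an aromatic carbon, stayed within the scatter. Compound 3 is therefore expected to give about 3000 nM in this assay, between 1000 nM and 9000 nM, an expected step of a 1.0-fold lower number from compound 2 to compound 3 (0.01 log units; within the scatter) that would not exceed the scatter.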

Compound 3, concentration for 50% growth inhibition: 2600 nM
Estimate against measurement, compound 3: 1.2-fold (0.06 log units) above; the range from low to high includes it.
By their numbers in this assay, from the lowest: compounds 1, 3 and 2 (each within the scatter of the next).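

Exchanging 3,4-dimethoxyphenyl on a carbonyl carbon for 3,4-difluorophenyl gives a 1.2-fold higher number from compound 1 to compound 3 (0.08 log units; within the scatter) in this assay, and exchanging 4-methoxyphenyl for it gives a 1.2-fold lower number from compound 2 to compound 3 (0.07 log units; within the scatter) in the same test. So, across these three compounds, this position holds an aryl ring carrying two fluorines and no methoxy without leaving the scatter, and a methoxy on that ring is not required for this level of growth inhibition. No supporting measurement bears on why the three compounds stay so close. Still open, on these data alone, is whether an amine or a carboxylic acid on this ring, or a longer chain in its place, would keep these numbers.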